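The source may report more compounds than this note shows. Statements on the series, on what has been measured and on what is new or still open speak of the compounds shown alone.

Compound 1 `CCc1nnc(SCc2ccccc2)n1N1C(=O)c2ccccc2C1=O`: in a functional assay on HepG2 cells (Homo sapiens) for cytotoxicity, read by MTT assay, with a stated time of 48 h (a lower number here means a stronger inhibitor, a higher number a weaker inhibitor), compound 1 gives only a limit, > 200000 nM.
Compound 2 `CCc1nnc(SCC(=O)c2ccc(Cl)cc2)n1N1C(=O)c2ccccc2C1=O`: in this assay compound 2 gives only a limit, > 200000 nM.
Compound 3 `CCCc1nnc(SCc2ccccc2)n1N1C(=O)c2ccccc2C1=O`: in this assay compound 3 gives only a limit, > 200000 nM.

The change from compound 1 to compound 2 is (4-chlorophenyl)carbonyl in place of phenyl on a saturated chain carbon bound to a sulfur, and its step reads a step that the two limits leave unreadable from compound 1 to compound 2. The two cores differ by methyl in place of hydrogen on a saturated chain carbon, two bonds along the chain from an aromatic carbon, with a step that the two limits leave unreadable from compound 1 to compound 3. Both steps stay unreadable because of the limit of > 200000 nM in this assay, at which 3 of the 3 values shown sit. Compound 4 `CCCc1nnc(SCC(=O)c2ccc(Cl)cc2)n1N1C(=O)c2ccccc2C1=O` carries the same change on the core of compound 3, ((4-chlorophenyl)carbonyl in place of phenyl on a saturated chain carbon bound to a sulfur), at a place told in the same words. Compound 4 is expected to give a step that the limit leaves unreadable from compound 3 to compound 4 in this assay, an expectation resting on (the limit of > 200000 nM in this assay, at which 3 of the 3 values shown sit). The estimate for compound 4 in this assay is therefore 250000 nM, expected to lie between 100000 nM and 600000 nM.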

Compound 4, half-maximal inhibitory concentration: > 200000 nM
Compound 4 gave a limit, no number (the forecaster's own chance of this, stated with the estimate: 85%); the middle value lies beyond the limit too.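

The steps to compound 4 from compound 3 and from compound 2 cannot be read, because the values give no number: the limit of > 200000 nM in this assay, at which 4 of the 4 values shown sit.

The compounds shown leave open what value any of them would reach in this assay, and so whether either change has any effect there.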